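Iodo for Bromo on the Phenyl Ester of Compound 3

The source may hold more compounds than are shown below. What is called first, only, known or untested is meant among the compounds shown, and "the series" means these compounds.

Compound 1 `NCc1ccc2oc(=O)c(C(=O)Oc3ccccc3)cc2c1` gives 85.5% in a functional assay on HT-1080 cells (Homo sapiens), read by transwell migration, with a stated time of 24 h, tested at 1 uM; on this read-out higher numbers stand for a weaker effect at the one concentration tested and lower numbers for a stronger effect.
Compound 2 `NCc1ccc2oc(=O)c(C(=O)Oc3cccc(F)c3)cc2c1` gives 45.3% in this assay.
Compound 3 `NCc1ccc2oc(=O)c(C(=O)Oc3cccc(Br)c3)cc2c1` gives 79.3% in this assay.

Compound 3 holds the second highest of the three numbers. Its nearest neighbour is compound 1, and the step of a number 6.2 percentage points lower from compound 1 to compound 3 (within the scatter) stays within the scatter, so the two cannot be ordered. Its furthest is compound 2, and the step of a number 34 percentage points higher from compound 2 to compound 3 (beyond the scatter) lies beyond the scatter, as does a number 40.2 percentage points lower from compound 1 to compound 2 (beyond the scatter).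

Compound 4 `NCc1ccc2oc(=O)c(C(=O)Oc3cccc(I)c3)cc2c1` differs from compound 3 by iodo in place of bromo on an aromatic carbon.

Among the measured compounds shown here, no measured step swaps bromo for iodo, so nothing bears directly on it. What is known is that hydrogen and bromo gave numbers within the scatter of each other, while fluoro alone stood apart. Compound 4 carries a group of the same kind as compound 3, and the step of a number 3.3 percentage points lower from compound 3 to compound 4 (within the scatter) is expected to remain within the scatter, with no direction beyond it claimed. Compound 4 is therefore estimated at 76% in this assay, with a range from 52% to 95%.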

Compound 4, a percentage reported as activity, at one concentration (the size of the read-out at that concentration, not a potency): 25.3%
Compound 4: middle estimate off by 50.7 percentage points, on the high side; the whole stated range lies above it.
By their numbers in this assay, from the lowest: compound 4; then compound 2; then compounds 3 and 1 (each within the scatter of the next).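

At this place on the phenyl ester, exchanging bromo for iodo moves the read-out of this assay sharply, with a number 54 percentage points lower from compound 3 to compound 4 (beyond the scatter) showing that two groups of the same family cannot be treated as interchangeable here. Among the compounds shown here, compound 4 also stands clear of the other two compounds, with a number 20 percentage points lower from compound 2 to compound 4 (beyond the scatter) and a number 60.2 percentage points lower from compound 1 to compound 4 (beyond the scatter) giving it the strongest effect of the four at the one concentration tested, so fluoro is no longer the only group that departs from hydrogen. Along fluoro, bromo and iodo the numbers follow no steady rise or fall, with compound 3 going against any such trend, and nothing available accounts for this.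

Going by these compounds, whether chloro at this place would group with bromo or with fluoro and iodo remains open, as does the outcome with a methoxy group or an amine there. Also open, on these data alone, is whether iodo would give a similar result elsewhere on the same ring, and whether the gap between the bromo and iodo compounds would persist at other concentrations.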